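Swapping the aryl sulfonyl group in a spirocyclic dienone series

The source may hold more compounds than are shown below. What is called first, only, known or untested is meant among the compounds shown, and "the series" means these compounds.

Compound 1 `Cc1ccc(S(=O)(=O)N2C(=O)COC23C=CC(=O)C=C3)cc1` gives > 10000 nM in a functional assay on HepG2 cells (Homo sapiens) for inhibition, read by sulforhodamine B assay, with a stated time of 74 h; on this read-out lower numbers stand for stronger inhibition and higher numbers for weaker inhibition.
Compound 2 `O=C1C=CC2(C=C1)OCC(=O)N2S(=O)(=O)c1ccc(N2CCCC2=O)cc1` gives > 10000 nM in this assay.

The value of compound 1 is a limit of the assay, not a number. The value of compound 2 is likewise only a limit. Among the measured compounds shown here, the one measured step, a step that the two limits leave unreadable from compound 1 to compound 2, therefore cannot be read, as both values sit at the limit (the limit of > 10000 nM in this assay, at which 2 of the 2 values shown sit). Compound 3 `O=C1C=CC2(C=C1)OCC(=O)N2S(=O)(=O)c1ccc(Br)s1` differs from compound 1 by 5-bromothiophen-2-yl in place of 4-methylphenyl on a sulfonyl sulfur. For the measured compounds named here, no measured step bears on this change, so compound 3 is expected to remain at or past the limit in this assay, with the step that the limit leaves unreadable from compound 1 to compound 3 expected to be unreadable. Compound 3 is estimated at 15000 nM, between 5000 nM and 50000 nM.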

Compound 3, half-maximal inhibitory concentration: 240 nM
Estimate against measurement, compound 3: 63-fold (1.80 log units) above; the whole stated range lies above it.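

In this assay, the group on the sulfonyl sulfur turns out to matter: 5-bromothiophen-2-yl in place of 4-methylphenyl gives an at least 41-fold lower number from compound 1 to compound 3 (1.61 log units; beyond the scatter), and a lower number means stronger inhibition. This single step changes both the ring and its substituent, so it cannot show which of the two accounts for the gain. Compound 3 is the only compound shown with a readable number, while the others remain at a limit: the limit of > 10000 nM in this assay, at which 2 of the 3 values shown sit.

From the compounds shown here alone, it remains open whether the bromine or the thiophene ring matters more. A plain thiophen-2-yl and a 4-bromophenyl group would separate the two, while an amine or a carboxylic acid in place of the bromine would test that position further.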